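Swapping a furan for a pyridine in a cooling-receptor agonist series

A few compounds are considered here, and "the series" means these few. Any claim that something is new, unique, unknown or untested is made for them only; others in the source may bear on it.

Measured so far:
compound 1 `CCN(Cc1ccoc1)C(=O)COc1ccc(C)cc1` — 136 nM
compound 2 `CCN(Cc1cccnc1)C(=O)COc1ccc(C)cc1` — 15400 nM
compound 3 `CCN(Cc1ccco1)C(=O)COc1ccc(C)cc1` — 489 nM

These three compounds share one core and differ only in the aromatic ring on a saturated chain carbon bound to an amide-type nitrogen. In an assay on HEK293 cells for agonist activity at transient receptor potential cation channel subfamily M member 8 (Homo sapiens), read by fluorescence and calcium flux, with a stated time of 15 min (on this read-out lower numbers stand for an effect already at smaller amounts and higher numbers for an effect only at larger amounts of compound), compound 3 stands second highest of the three numbers: its nearest neighbour is compound 1, with a 3.6-fold higher number from compound 1 to compound 3 (0.56 log units; beyond the scatter), and its furthest is compound 2, with a 31-fold lower number from compound 2 to compound 3 (1.50 log units; beyond the scatter).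

Compound 4 `CCN(Cc1ccncc1)C(=O)COc1ccc(C)cc1` has not been measured. Relative to compound 3 the change is pyridin-4-yl in place of furan-2-yl on a saturated chain carbon bound to an amide-type nitrogen. Going by the values given here, two measured steps bear on it, both replacing a furan ring with a pyridine ring at this place: a 110-fold higher number from compound 1 to compound 2 (2.05 log units; beyond the scatter) and, read the other way, a 31-fold lower number from compound 2 to compound 3 (1.50 log units; beyond the scatter). Both are large and both put the pyridine compound at the higher number. The pyridine in compound 4 carries its nitrogen at a different ring position than in compound 2, and nothing measured here shows how that matters, so the expectation rests on the two furan-to-pyridine steps alone. A large rise beyond the scatter is therefore expected, in this assay, from compound 3 to compound 4, about a 25-fold higher number from compound 3 to compound 4 (1.39 log units; beyond the scatter). Compound 4 is estimated at 12000 nM, with a range from 3000 nM to 50000 nM.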

Compound 4, half-maximal effective concentration: "not active" (no number reported)
The entry for compound 4 holds no number; the estimate stays without a comparison.
By their numbers in this assay, from the lowest: compound 1; then compound 3; then compound 2.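

Going by these compounds alone, compound 4 is reported only as "not active", with no number, so no step from compound 3 or any other compound to compound 4 can be read. The compounds shown leave open whether pyridin-4-yl and pyridin-3-yl differ at this place, as compound 4 and compound 2 cannot be compared. Nothing shown offers an explanation for this result.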